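A few compounds are considered here, and "the series" means these few. Any claim that something is new, unique, unknown or untested is made for them only; others in the source may bear on it.

Compound 2 `Cc1ccnc(Oc2ccc(CC3SC(=O)NC3=O)cc2)c1` gives 4280 nM in a functional assay for agonist activity at Free fatty acid receptor 1 (Homo sapiens), read by FLIPR, in the presence of a further agent that is not named here (on this read-out lower numbers stand for an effect already at smaller amounts and higher numbers for an effect only at larger amounts of compound), the highest of the three numbers recorded. Compound 1 `Cc1cc(Oc2ccc(CC3SC(=O)NC3=O)cc2)nc(C(F)(F)F)c1` gives 688 nM, and compound 3 `O=C1NC(=O)C(Cc2ccc(Oc3cc(C(F)(F)F)ccn3)cc2)S1` gives 237 nM. The step of a 6.2-fold higher number from compound 1 to compound 2 (0.79 log units; beyond the scatter) and the step of an 18-fold lower number from compound 2 to compound 3 (1.26 log units; beyond the scatter) both show that the groups on the aromatic ring attached to the oxygen move the read-out well beyond the scatter. Compound 4 `O=C1NC(=O)C(Cc2ccc(Oc3ccccc3Cl)cc2)S1` differs from compound 2 by 2-chlorophenyl in place of 4-methylpyridin-2-yl on an oxygen on an aromatic ring. Neither measured step exchanges the ring itself, so they bear on this change only indirectly: they show that compound 2, as the weakest of the three, leaves room for lower numbers. The step of a 2.9-fold lower number from compound 2 to compound 4 (0.46 log units; beyond the scatter) is therefore expected to be modest and downward, with wide uncertainty. Compound 4 is expected to give 1500 nM, in a range from 300 nM to 8000 nM.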

Compound 4, half-maximal effective concentration: 1190 nM
Compound 4: the middle estimate sits 1.3-fold (0.10 log units) above what was measured; measured number inside the range.
By their numbers in this assay, from the lowest: compound 3; then compounds 1 and 4 (each within the scatter of the next); then compound 2.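

In this assay, among the compounds shown here, the step of a 3.6-fold lower number from compound 2 to compound 4 (0.56 log units; beyond the scatter) is the first here to exchange the whole ring on the oxygen rather than a group on it. It shows that 2-chlorophenyl, a ring of carbon only, can take the place of 4-methylpyridin-2-yl and still give a lower number, so the ring nitrogen is not needed for that. No measurement shown accounts for this step.

The compounds shown leave open what a nitrile or a methoxy group in place of the chlorine would give. They also leave open whether trifluoromethyl would lower the number on this carbon-only ring too.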